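The compounds below may be only part of what the source reports. "The series", "measured", "known", "first", "only" and "open" are said of these compounds alone.

Measured compounds in an ADME assay on Raji cells (Homo sapiens) for cytotoxicity, with a stated time of 72 h; a lower number here means that less compound is needed, a higher number that more compound is needed for the effect:
- compound 1, `COc1ccc(NC(=O)Nc2cc(C)nc3ccccc23)cc1`: > 25000 nM
- compound 2, `COc1ccc(NC(=O)Nc2cc(C)nc3ccccc23)cc1Cl`: > 25000 nM
- compound 3, `COc1ccc(NC(=O)Nc2cc(C)nc3ccccc23)cc1OC`: > 25000 nM

Compound 1 sits at a limit of this assay rather than at a number: > 25000 nM is the reading. The same holds for compound 2, whose reading of > 25000 nM is a limit. For compound 3 the reading of > 25000 nM is likewise a limit. All three share (the limit of > 25000 nM in this assay, at which 3 of the 3 values shown sit), so the three steps among them, a step that the two limits leave unreadable from compound 1 to compound 2, a step that the two limits leave unreadable from compound 1 to compound 3 and a step that the two limits leave unreadable from compound 2 to compound 3, cannot be read; the chloro or methoxy entering on the aromatic carbon gives no readable shift in this assay.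

Compound 4, `Cc1cc(NC(=O)Nc2ccc(C(C)(C)C)cc2)c2ccccc2n1`, has not yet been measured in this assay. It differs from compound 1 by tert-butyl in place of methoxy on an aromatic carbon. Among the compounds with values here, none of the measured steps is readable, so there is no direct evidence on how a tert-butyl at this place moves the read-out. Within the data shown here, the only guide is that every change so far has left the series at the limit, which is due to the limit of > 25000 nM in this assay, at which 3 of the 3 values shown sit. The expectation is therefore that compound 4 also stays at or near that limit, with an expected step of a number no higher from compound 1 to compound 4 (the limit leaves the size open) that is not beyond the scatter. The estimate for compound 4 in this assay is 25000 nM, with an expected range from 8000 nM to 60000 nM.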

Compound 4, half-maximal effective concentration: > 25000 nM
Compound 4: only a limit was reported; the forecaster's own chance of this, stated with the estimate: 75%; the middle value sits exactly at the limit.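

In this assay compound 4 gives > 25000 nM, which is a limit. Within the data shown here, the change from compound 1 to compound 4, tert-butyl in place of methoxy, therefore gives no step that can be read: the limit of > 25000 nM in this assay, at which 4 of the 4 values shown sit. The compounds shown leave open how far any of these groups on the aromatic carbon moves the read-out.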